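Extending an ester chain on a calcium channel blocker

The source may hold more compounds than are shown below. What is called first, only, known or untested is meant among the compounds shown, and "the series" means these compounds.

Compound 2 `CCOC(=O)C1=C(C)NC(C)=C(C(=O)OC)C1c1[nH]c(CC)nc1Cl` stands at the weak end of the three measured compounds: in an assay on ileum for inhibition of Voltage-dependent L-type calcium channel subunit alpha-1C (Cavia porcellus) (on this read-out higher numbers stand for weaker inhibition and lower numbers for stronger inhibition), compound 2 gives 2.02 nM. Compound 1 `CCc1nc(Cl)c(C2C(C(=O)OC)=C(C)NC(C)=C2C(=O)OC)[nH]1` gives 0.596 nM, and compound 3 `CCOC(=O)C1=C(C)NC(C)=C(C(=O)OCC)C1c1[nH]c(CC)nc1Cl` gives 0.158 nM, the strongest of the three. Compound 4 `CCCOC(=O)C1=C(C)NC(C)=C(C(=O)OC)C1c1[nH]c(CC)nc1Cl` differs from compound 2 by methyl in place of hydrogen on a saturated chain carbon, two bonds along the chain from an oxygen next to a carbonyl group. Going by the values given here, no measured step matches this change; the two known steps alter a different position, one bond closer to the oxygen: a 3.4-fold higher number from compound 1 to compound 2 (0.53 log units; beyond the scatter) and a 13-fold lower number from compound 2 to compound 3 (1.11 log units; beyond the scatter), pulling in opposite directions. Among the compounds with values here, with no direct precedent, only a modest shift is expected, most likely downward, so the estimate for compound 4 is a 1.6-fold lower number from compound 2 to compound 4 (0.19 log units; within the scatter), giving 1.3 nM within 0.35 nM to 5 nM.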

Compound 4, half-maximal inhibitory concentration: 0.146 nM
For compound 4 the middle estimate is 8.9-fold (0.95 log units) above the measured one, and the stated range ends above it.
By their numbers in this assay, from the lowest: compounds 4 and 3 (each within the scatter of the next); then compound 1; then compound 2.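

In this assay, the outer end of this ester chain clearly matters: going from ethyl to propyl, with methyl in place of hydrogen two bonds along the chain from the oxygen, gives a large gain (a 14-fold lower number from compound 2 to compound 4 (1.14 log units; beyond the scatter)). The loss seen on first lengthening the chain from compound 1 to compound 2 therefore does not continue, and the propyl ester also surpasses the original methyl ester (a 4.1-fold lower number from compound 1 to compound 4 (0.61 log units; beyond the scatter)). Nothing available explains this reversal.

As far as these compounds go, it remains open whether a longer chain such as butyl, a branched isopropyl group or a terminal amine would hold this gain.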